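This account rests on a few compounds, and the source may have more. Where it says the series, first, only, none or still open, it means among the compounds named here.

Compound 1 `COc1cccc(C(=O)Nc2cccc(-c3oc4cc(-c5ccc(F)cc5)ccc4c(=O)c3O)c2)c1` gives 18900 nM in a functional assay on HCC1937 cells (Homo sapiens) for antiproliferative activity, read by CCK-8 assay, with a stated time of 72 h; on this read-out higher numbers stand for weaker inhibition and lower numbers for stronger inhibition.
Compound 2 `Cc1cc(C)cc(C(=O)Nc2cccc(-c3oc4cc(-c5ccc(F)cc5)ccc4c(=O)c3O)c2)c1` gives 4860 nM in this assay.
Compound 3 `N#Cc1ccc(C(=O)Nc2cccc(-c3oc4cc(-c5ccc(F)cc5)ccc4c(=O)c3O)c2)cc1` gives 2990 nM in this assay.

All three share one core, and they differ only in the aromatic group attached to the amide carbonyl. Compound 1, which carries the 3-methoxyphenyl group there, has the highest number of the three, meaning the weakest inhibition. Its nearest neighbour is compound 2, reached by a 3.9-fold lower number from compound 1 to compound 2 (0.59 log units; beyond the scatter). Its furthest is compound 3, reached by a 6.3-fold lower number from compound 1 to compound 3 (0.80 log units; beyond the scatter). The two lower numbers sit close together: a 1.6-fold lower number from compound 2 to compound 3 (0.21 log units; within the scatter), so no order between compound 2 and compound 3 can be read from them.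

Compound 4 `O=C(Nc1cccc(-c2oc3cc(-c4ccc(F)cc4)ccc3c(=O)c2O)c1)c1ccc(-c2ccccc2)cc1` has not yet been measured in this assay. It differs from compound 1 in the same position as the other two: 4-phenylphenyl in place of 3-methoxyphenyl on a carbonyl carbon. Both measured steps that swap the 3-methoxyphenyl group for another phenyl group, whether 3,5-dimethylphenyl or 4-cyanophenyl, gave lower numbers beyond the scatter, and both were modest. Neither of them tried a second ring, so the size of the new step is uncertain, but the direction is expected to be the same. For compound 4 a step of a 4.7-fold lower number from compound 1 to compound 4 (0.67 log units; beyond the scatter) is expected, and the estimated value is 4000 nM, most likely between 1200 nM and 13000 nM.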

Compound 4, half-maximal inhibitory concentration: 44100 nM
Beside the measured number, compound 4's estimate is 11-fold (1.04 log units) below it; measured number outside the range, above it.
By their numbers in this assay, from the lowest: compounds 3 and 2 (each within the scatter of the next); then compound 1; then compound 4.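

Swapping the 3-methoxyphenyl group for 4-phenylphenyl on the carbonyl carbon reverses the direction seen so far in this assay (a 2.3-fold higher number from compound 1 to compound 4 (0.37 log units; beyond the scatter)), so a change at this position does not always lower the number. Among these compounds, the gap is wider against the other two compounds (a 15-fold higher number from compound 3 to compound 4 (1.17 log units; beyond the scatter); a 9.1-fold higher number from compound 2 to compound 4 (0.96 log units; beyond the scatter)), and the position can therefore separate these aromatic groups clearly, with compound 4, the only compound here with two rings in this group, giving a higher number than all three single-ring compounds, although one such compound cannot establish a rule for two-ring groups. No measurement at hand explains this reversal.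

The compounds shown leave open whether any second ring at this position raises the number or only this added phenyl does, and a naphthyl or 4-morpholinophenyl group would bear on that question. They also leave open how a carboxylic acid or an aliphatic amine on a short chain would behave on the same carbonyl carbon.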